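A few compounds are considered here, and "the series" means these few. Any claim that something is new, unique, unknown or untested is made for them only; others in the source may bear on it.

Measured so far in an ADME assay on microsomes from liver (Rattus norvegicus) for metabolic stability, with a stated time of 30 min, tested at 1 uM; on this read-out higher numbers stand for a more stable compound and lower numbers for a less stable compound:
compound 1 `CCc1ccc(Nc2nc(C)cs2)cc1` gives 0%
compound 2 `CCCCCc1ccc(Nc2nc(C)cs2)cc1` gives 3%

Compound 1 stands lowest of the two numbers; the step to its nearest neighbour, a number 3 percentage points higher from compound 1 to compound 2 (within the scatter), lies within the scatter. Compound 3 `Cc1csc(Nc2ccc(OC3CCCC3)cc2)n1` is not yet measured in this assay. It differs from compound 1 by cyclopentyloxy in place of ethyl on an aromatic carbon. Among the compounds with values here, no measured step bears directly on this change: the only measured step, a number 3 percentage points higher from compound 1 to compound 2 (within the scatter), concerns another position and was within the scatter, and both measured compounds sit near the floor of the read-out. Nothing in these numbers supports a step beyond the scatter, so the step of a number 5 percentage points higher from compound 1 to compound 3 (within the scatter) is expected to stay small. Compound 3 is therefore estimated at 5%, in a range from 0% to 25%.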

Compound 3, percent of the compound remaining: 10%
Compound 3: middle estimate off by 5 percentage points, on the low side; the measured number falls inside the stated range.
By their numbers in this assay, from the lowest: compounds 1, 2 and 3 (each within the scatter of the next).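

Cyclopentyloxy brings an oxygen and a five-membered ring to the aromatic carbon that holds ethyl in compound 1 and pentyl in compound 2. In this assay the steps of a number 10 percentage points higher from compound 1 to compound 3 (within the scatter) and a number 7 percentage points higher from compound 2 to compound 3 (within the scatter) show that this exchange, for either chain, stays within the scatter, and all three compounds remain at the low end of the read-out. No evidence bears on this result. Open, on these data alone, is whether an amine or a carboxylic acid on this aromatic carbon would give a step beyond the scatter.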